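Swapping a large group for cyclopropyl

This account rests on a few compounds, and the source may have more. Where it says the series, first, only, none or still open, it means among the compounds named here.

Within the data shown here, in an ADME assay on microsomes from liver (Homo sapiens) for metabolic stability, using NADPH, with a stated time of 10 min (a lower number here means that less of the compound is left, a higher number that more of the compound is left), compound 1 `CCCCc1nc(=O)c(S(=O)(=O)c2ccc(-c3ccnc(NC(=O)C4CC4)c3)cc2)c(O)n1-c1c(OC)cccc1OC` gives 84% and stands highest of the two numbers so far. Compound 2 `CCCCc1[nH]c(=O)c(S(=O)(=O)c2ccc(-c3cccnc3OC)cc2)c(O)c1-c1c(OC)cccc1OC` gives 72% and sits lower, beyond the usual scatter. Compound 3 `CCCCc1nc(=O)c(S(=O)(=O)c2ccc(C3CC3)cc2)c(O)n1-c1c(OC)cccc1OC` has cyclopropyl in place of 2-((cyclopropylcarbonyl)amino)pyridin-4-yl on an aromatic carbon. Among the measured compounds shown here, no measured pair shows this kind of change, so any forecast stays loose. The estimated step of a number 6 percentage points lower from compound 1 to compound 3 (within the scatter) is a small expected fall that stays within the scatter. For compound 3 the expected value is 78% with an estimated range from 60% to 92% in this assay.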

Compound 3, percent of the compound remaining: 95%
Compound 3: the middle estimate sits 17 percentage points below what was measured, and the stated range ends below it.
By their numbers in this assay, from the lowest: compound 2; then compound 1; then compound 3.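

In this assay, putting cyclopropyl in place of 2-((cyclopropylcarbonyl)amino)pyridin-4-yl gives a number 11 percentage points higher from compound 1 to compound 3 (beyond the scatter). At this aromatic carbon, then, the large group can be exchanged for a far smaller one with more of the compound left, not less. No measurement here gives a reason for this rise.

This single pair cannot separate an effect of cyclopropyl itself from an effect of losing the larger group. Methyl or an amine on the same carbon would help to tell these apart.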